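A few compounds are considered here, and "the series" means these few. Any claim that something is new, unique, unknown or untested is made for them only; others in the source may bear on it.

Compound 1 `COc1cc(OCC=C(C)C)ccc1C(=O)/C=C/c1ccncc1` is the reference point of this small set. Among the compounds with values here, in an ADME assay on THP-1 cells (Homo sapiens) for cytotoxicity, read by resazurin assay, with a stated time of 72 h (on this read-out higher numbers stand for lower toxicity in this test and lower numbers for higher toxicity in this test), compound 1 gives 16000 nM, the lowest number among the three compounds measured so far. Its nearest neighbour is compound 2 `COc1cc(OCC=C(C)C)ccc1C(=O)/C=C/c1ccc(Br)cc1`, which gives 100000 nM in this assay; the step is a 6.3-fold higher number from compound 1 to compound 2 (0.80 log units; beyond the scatter). Furthest away stands compound 3 `COc1cc(OCC=C(C)C)ccc1C(=O)/C=C/c1ccc([N+](=O)[O-])cc1`, which gives 600000 nM in this assay, and that step is a 38-fold higher number from compound 1 to compound 3 (1.57 log units; beyond the scatter). Between the two substituted phenyl compounds the step is a 6.0-fold higher number from compound 2 to compound 3 (0.78 log units; beyond the scatter).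

Compound 4 `COc1cc(OCC=C(C)C)ccc1C(=O)/C=C/c1ccccc1` has not yet been measured in this assay. It differs from compound 1 in one place: phenyl in place of pyridin-4-yl on a double-bonded chain carbon bound to a double-bonded chain carbon. The two measured steps from compound 1 both replace pyridin-4-yl with a phenyl carrying a group on an aromatic carbon, and both run toward higher numbers, one modest and one large. The change to an unsubstituted phenyl is of the same kind, so a step upward from compound 1 beyond the scatter is expected, though its size between the two precedents is uncertain.

For compound 4 the expected step is a 3.8-fold higher number from compound 1 to compound 4 (0.57 log units; beyond the scatter), giving an estimate of 60000 nM in this assay, with a range from 16000 nM to 250000 nM.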

Compound 4, half-maximal cytotoxic concentration: 50000 nM
Beside the measured number, compound 4's estimate is 1.2-fold (0.08 log units) above it; the range from low to high includes it.
By their numbers in this assay, from the lowest: compound 1; then compounds 4 and 2 (each within the scatter of the next); then compound 3.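

Compound 4 carries no further group on the ring, so it isolates the exchange of pyridin-4-yl for phenyl on this chain carbon: in this assay the change alone gives a 3.1-fold higher number from compound 1 to compound 4 (0.49 log units; beyond the scatter) and so lies beyond the scatter without help from any added group. The earlier compounds shown here could not separate the ring exchange from the effect of the bromo or nitro group, but hydrogen and bromo on the aromatic carbon now cannot be told apart, with a 2.0-fold lower number from compound 2 to compound 4 (0.30 log units; within the scatter) within the scatter. Nitro does stand apart from hydrogen, with a 12-fold lower number from compound 3 to compound 4 (1.08 log units; beyond the scatter), so among the phenyl compounds shown only compound 3 departs from the level that compound 4 sets, and the step from pyridin-4-yl to a phenyl ring is not the whole of its distance from compound 1.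

The compounds shown leave open whether an amine or a carboxylic acid on the aromatic carbon would stay level with hydrogen and bromo or move away as nitro does. No independent measurement bears on these differences, and what lies behind them remains unexplained.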